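Adding a Methoxy Group: Expected Effect on Deacetylase Inhibition

The source may report more compounds than this note shows. Statements on the series, on what has been measured and on what is new or still open speak of the compounds shown alone.

Three compounds have been measured in an in vitro assay on cells for inhibition of protein deacetylase HDAC6 (Homo sapiens), read by fluorescence, with a stated time of 3 h; on this read-out lower numbers stand for stronger inhibition and higher numbers for weaker inhibition:

Compound 1 `COc1ccc(/C=C/C(=O)NCCCN2CCc3nc(C(=O)NO)sc3C2)cc1`: 8770 nM
Compound 2 `C=CCCC(=O)NCCCCN1CCc2nc(C(=O)NO)sc2C1`: 24800 nM
Compound 3 `O=C(/C=C/c1ccccc1)NCCCCN1CCc2nc(C(=O)NO)sc2C1`: 23200 nM

Compound 3 stands second highest of the three numbers. Its nearest neighbour is compound 2, and the step of a 1.1-fold lower number from compound 2 to compound 3 (0.03 log units; within the scatter) lies within the scatter, so these two cannot be told apart. Compound 1, which carries a methoxy group and a shorter chain, shows a clearly lower number than compound 3, beyond the scatter.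

Compound 4 `COc1ccc(/C=C/C(=O)NCCCCN2CCc3nc(C(=O)NO)sc3C2)cc1` differs from compound 3 by methoxy in place of hydrogen on an aromatic carbon. Going by the values given here, no measured step isolates this change alone. Among the compounds with values here, the only guide is that compound 1, the methoxy-bearing compound, gives a lower number than compound 3, although it also differs in chain length. A modest lowering is therefore expected, as a 1.9-fold lower number from compound 3 to compound 4 (0.29 log units; within the scatter). For compound 4 the estimated value in this assay is 12000 nM, with a range from 5000 nM to 30000 nM.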

Compound 4, half-maximal inhibitory concentration: 9550 nM
Compound 4: middle estimate off by 1.3-fold (0.10 log units), on the high side, within the range that was stated.
By their numbers in this assay, from the lowest: compounds 1 and 4 (each within the scatter of the next); then compounds 3 and 2 (each within the scatter of the next).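

Methoxy on the six-membered aromatic ring, para to a large group, can now be read as a single change: in this assay it gives a 2.4-fold lower number from compound 3 to compound 4 (0.39 log units; beyond the scatter) and so has a measurable effect at this position. Phenyl alone did not do this, since 2-phenylethenyl in place of but-3-en-1-yl gave only a 1.1-fold lower number from compound 2 to compound 3 (0.03 log units; within the scatter) whereas 2-(4-methoxyphenyl)ethenyl in its place gives a 2.6-fold lower number from compound 2 to compound 4 (0.41 log units; beyond the scatter) and so a change appears only with the methoxy present. No measurement shown here explains this lowering.

Going by these compounds, whether an ethoxy, a hydroxyl or a fluorine on the same carbon would do the same remains open, as does methoxy on the other ring carbons. A longer chain is also untested here: compound 1, with its shorter chain, and compound 4 lie within the scatter of each other.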